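The compounds below may be only part of what the source reports. "The series", "measured", "known", "first", "only" and "open" are said of these compounds alone.

Series notes, step from compound 3 to compound 4.

Compound 1 `C(=C/c1ccccc1OCCCCN1CCCCC1)\c1ccccc1` carries the parent piperidine; in a functional assay on the whole organism with Mus musculus as the target, in the maximal electroshock model, at a dose of 50 mg/kg by the oral route (on this read-out lower numbers stand for less inhibition and higher numbers for more inhibition at the one dose given (going by the name of the read-out)), compound 1 gives 42.9%. Compound 2 `OC1CCN(CCCCOc2ccccc2/C=C/c2ccccc2)CC1` puts a hydroxy on the saturated ring, and in this assay compound 2 gives 0%. Compound 3 `C(=C/c1ccccc1OCCCCN1CCNCC1)\c1ccccc1` exchanges the ring for piperazine, and in this assay compound 3 gives 0%. Two steps lead down to the floor: a number 42.9 percentage points lower from compound 1 to compound 2 (beyond the scatter) and a number 42.9 percentage points lower from compound 1 to compound 3 (beyond the scatter), both large. Between the two low compounds nothing moves: no change at the digits printed from compound 2 to compound 3 (within the scatter). Compound 3 therefore stands level with compound 2 at the bottom of the three numbers, and well under compound 1.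

Compound 4 `CCN1CCN(CCCCOc2ccccc2/C=C/c2ccccc2)CC1` differs from compound 3 by ethyl in place of hydrogen on an amine nitrogen in a ring. For the measured compounds named here, no measured step touches the ring amine nitrogen itself, so the change is untested here. The only nearby evidence is that the piperazine ring in compound 3 sits at the floor, and that the hydroxy in compound 2 sat there as well, so this position has so far shown no way back up. For compound 4 the expected step is a number 10 percentage points higher from compound 3 to compound 4 (within the scatter), most likely none beyond the scatter. Compound 4 is estimated at 10%, within 0% to 35%.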

Compound 4, a percentage reported as inhibition, in the whole organism at one dose (the size of the read-out at that dose, not a potency): 33.3%
Compound 4: middle estimate off by 23.3 percentage points, on the low side, and the stated range covers the measured number.
By their numbers in this assay, from the lowest: compounds 2 and 3 (each within the scatter of the next); then compounds 4 and 1 (each within the scatter of the next).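

In this assay, the amine nitrogen in the ring turns out to be a position where a single substitution can lift a compound off the floor: ethyl in place of hydrogen gives a number 33.3 percentage points higher from compound 3 to compound 4 (beyond the scatter), so the piperazine ring does not by itself fix the read-out at the bottom. The new group also separates the two rings that had looked alike, with 4-ethylpiperazin-1-yl in place of 4-hydroxypiperidin-1-yl giving a number 33.3 percentage points higher from compound 2 to compound 4 (beyond the scatter), while 4-ethylpiperazin-1-yl in place of piperidin-1-yl gives a number 9.6 percentage points lower from compound 1 to compound 4 (within the scatter), which leaves the ethylated piperazine and the parent piperidine indistinguishable at this one dose. No supporting data are available to explain the rise.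

The compounds shown leave open whether the effect is specific to ethyl or extends to other groups on this nitrogen, such as methyl, propyl, benzyl or acetyl. For the compounds shown here, it also remains open whether 4-ethylpiperazin-1-yl holds its level on a shorter or longer chain than the one shared by these compounds.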